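The source may hold more compounds than are shown below. What is called first, only, known or untested is meant among the compounds shown, and "the series" means these compounds.

Compound 1 `CCCS(=O)(=O)Nc1ccc(-c2cn3c(C(=O)OCC)csc3n2)cc1` gives in a functional assay on MV4-11 cells (Homo sapiens) for cytotoxicity, read by MTT assay, with a stated time of 72 h (on this read-out higher numbers stand for weaker inhibition and lower numbers for stronger inhibition), a value of > 20000 nM, which is a limit of the assay. Compound 2 `CCOC(=O)c1csc2nc(-c3ccc(NS(=O)(=O)c4ccc(C)cc4)cc3)cn12` gives > 20000 nM, likewise a limit.

Compound 2 therefore stands at the limit, where every value shown sits (the limit of > 20000 nM in this assay, at which 2 of the 2 values shown sit). The step that the two limits leave unreadable from compound 1 to compound 2 cannot be read. Compound 3 `CCOC(=O)c1csc2nc(-c3ccc(NC(=O)Nc4ccccc4)cc3)cn12` differs from compound 2 in one place: phenylcarbamoyl in place of (4-methylphenyl)sulfonyl on a nitrogen on an aromatic ring. No readable measured step bears on this change, so no direction can be expected beyond the scatter. Compound 3 is expected to remain near the limit, estimated at 20000 nM within 5000 nM to 60000 nM. The expected step is a number no higher from compound 2 to compound 3 (the limit leaves the size open).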

Compound 3, half-maximal inhibitory concentration: > 20000 nM
Compound 3 gave a limit, no number; the forecaster's own chance of this, stated with the estimate: 70%; the middle value sits exactly at the limit.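

No step can be read among compound 1, compound 2 and compound 3, as each gives only a limit and no number: the limit of > 20000 nM in this assay, at which 3 of the 3 values shown sit.

The compounds shown leave open whether propylsulfonyl, (4-methylphenyl)sulfonyl or phenylcarbamoyl on the nitrogen makes any difference.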